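Aryl hydrazone variation on the shared core

A few compounds are considered here, and "the series" means these few. Any claim that something is new, unique, unknown or untested is made for them only; others in the source may bear on it.

For the measured compounds named here, compound 2 `CN(C)CCn1cnnc1-c1cc(Oc2ccc(NC(=O)N/N=C/c3c(O)ccc4ccccc34)cc2F)ccn1` holds the lowest number measured so far in a functional assay on HT-29 cells (Homo sapiens) for cytotoxicity, read by MTT assay, with a stated time of 72 h (a higher number here means a weaker inhibitor, a lower number a stronger inhibitor), where compound 2 gives 670 nM. The nearest value belongs to compound 1 `CN(C)CCn1cnnc1-c1cc(Oc2ccc(NC(=O)N/N=C/c3ccc(F)cc3F)cc2F)ccn1`, which in this assay gives 960 nM; the step of a 1.4-fold lower number from compound 1 to compound 2 (0.16 log units; within the scatter) lies within the scatter, so the two compounds cannot be ranked against each other on these numbers. Compound 3 `CN(C)CCn1cnnc1-c1cc(Oc2ccc(NC(=O)N/N=C/c3cc(Br)c(O)c(Br)c3)cc2F)ccn1` has not yet been measured. It differs from compound 2 in one place: 3,5-dibromo-4-hydroxyphenyl in place of 2-hydroxynaphthalen-1-yl on a carbon with a double bond to nitrogen. Going by the values given here, the only measured step that bears on this change is the one at the same place, a 1.4-fold lower number from compound 1 to compound 2 (0.16 log units; within the scatter), an exchange of the group on the carbon with a double bond to nitrogen that left the number within the scatter. With one such step available and no other comparison in the series, no move beyond the scatter is expected for compound 3, and the estimated step is a 1.2-fold higher number from compound 2 to compound 3 (0.08 log units; within the scatter). Compound 3 is accordingly expected to give 800 nM in this assay, with an estimated range from 300 nM to 2500 nM.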

Compound 3, half-maximal inhibitory concentration: 2670 nM
Compound 3: middle estimate off by 3.3-fold (0.52 log units), on the low side; measured number outside the range, above it.
By their numbers in this assay, from the lowest: compounds 2 and 1 (each within the scatter of the next); then compound 3.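

In this assay, the group on the carbon with a double bond to nitrogen now shows an effect beyond the scatter, with 3,5-dibromo-4-hydroxyphenyl giving the highest number of the three compounds (a 4.0-fold higher number from compound 2 to compound 3 (0.60 log units; beyond the scatter); a 2.8-fold higher number from compound 1 to compound 3 (0.44 log units; beyond the scatter)). Both steps are modest, but unlike the earlier exchange (a 1.4-fold lower number from compound 1 to compound 2 (0.16 log units; within the scatter)), they show that this position does not accept every aryl group with the same result. A hydroxyl stands on the group in both compound 2 and compound 3, so its presence alone does not keep the number level, and no measurement at hand explains the rise.

The step from compound 2 to compound 3 replaces two six-membered aromatic rings with one and also brings in two bromines, so the compounds shown cannot separate these changes. Also open, on these data alone, is how the number responds to a plain 4-hydroxyphenyl without bromine, or to a group of another kind at this position, such as a carboxylic acid or an amine.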